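From Compound 3 to Compound 4: Adding a Methoxy

This account rests on a few compounds, and the source may have more. Where it says the series, first, only, none or still open, it means among the compounds named here.

Compound 3 `C[C@@]1(c2cc(NC(=O)c3ccc(C#N)cn3)ccc2F)C=C(CF)OC(N)=N1` gives the lowest of the three numbers in a physicochemical assay for lipophilicity, read by HPLC, in phosphate buffer, measured as octanol-water partition, with a stated time of 1 h, at pH 7.4 (on this read-out lower numbers stand for lower lipophilicity and higher numbers for higher lipophilicity), at 2.3. Compound 2 `C[C@@]1(c2cc(NC(=O)c3ncc(C#N)cc3Cl)ccc2F)C=C(CF)OC(N)=N1` gives 2.5 and compound 1 `C[C@@]1(c2cc(NC(=O)c3cnc(OCF)cn3)ccc2F)C=C(CF)OC(N)=N1` gives 2.6. Both gaps are small: a number 0.20 log units lower from compound 2 to compound 3 (within the scatter) and a number 0.30 log units lower from compound 1 to compound 3 (within the scatter). Compound 4 `COc1cc(C#N)cnc1C(=O)Nc1ccc(F)c([C@]2(C)C=C(CF)OC(N)=N2)c1` differs from compound 3 in one place: methoxy in place of hydrogen on an aromatic carbon. The step that bears most on this is a number 0.20 log units lower from compound 2 to compound 3 (within the scatter), where a chloro on the same aromatic carbon region was removed. Changing the whole group on the carbonyl carbon gave a number 0.10 log units lower from compound 1 to compound 2 (within the scatter), also small. A methoxy entering is expected to move the number no more than these did, so compound 4 is estimated at 2.4, between 2 and 2.8. That expected step is a number 0.10 log units higher from compound 3 to compound 4 (within the scatter).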

Compound 4, distribution coefficient: 1.9
Estimate against measurement, compound 4: 0.50 log units above; measured number below the stated range.
By their numbers in this assay, from the lowest: compound 4; then compounds 3, 2 and 1 (each within the scatter of the next).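

In this assay this aromatic carbon, ortho to a large group, now gives a step beyond the scatter: methoxy in place of hydrogen gives a number 0.40 log units lower from compound 3 to compound 4 (beyond the scatter) here, whereas the earlier swap of chloro for hydrogen stayed within it. Methoxy in place of chloro gives a number 0.60 log units lower from compound 2 to compound 4 (beyond the scatter) on the same carbon, and exchanging the whole group on the carbonyl carbon gives a number 0.70 log units lower from compound 1 to compound 4 (beyond the scatter) for the widest step in this set. Nothing measured here offers a reason for these drops. Going by these compounds, only hydrogen, chloro and methoxy appear on this carbon, so what an amine or an ethoxy would do remains open.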